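Replacing Bromo with Dimethylamino on the Shared Core

A few compounds are considered here, and "the series" means these few. Any claim that something is new, unique, unknown or untested is made for them only; others in the source may bear on it.

Of the compounds shown here, three sharing one core have been tested so far. Compound 1 `O=C1C=CCC/C1=C\C=C\c1ccccc1` carries an unsubstituted aromatic ring; in a functional assay on HGC-27 cells (Homo sapiens) for cytotoxicity, read by MTT assay, with a stated time of 72 h (a lower number here means a stronger inhibitor, a higher number a weaker inhibitor), compound 1 gives 4500 nM. Compound 2 `Cc1ccc(/C=C/C=C2\CCC=CC2=O)cc1` adds a methyl group to that ring, and compound 2 gives 8100 nM. Compound 3 `O=C1C=CCC/C1=C\C=C\c1ccc(Br)cc1` carries a bromo group instead, and compound 3 gives 4500 nM. On these numbers compound 3 stands level with compound 1 at the digits shown, the two together holding the lowest values of the three, with compound 2 the furthest away.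

The next compound, compound 4 `CN(C)c1ccc(/C=C/C=C2\CCC=CC2=O)cc1`, differs from compound 3 in one place: dimethylamino in place of bromo on an aromatic carbon.

Within the data shown here, the steps that bear on this are the earlier changes of the group on that aromatic ring: no change at the digits printed from compound 1 to compound 3 (within the scatter), a 1.8-fold lower number from compound 2 to compound 3 (0.26 log units; within the scatter) and a 1.8-fold higher number from compound 1 to compound 2 (0.26 log units; within the scatter). Each stayed within the scatter, so swapping that group has so far left the read-out essentially unmoved. Among the measured compounds shown here, a dimethylamino group has not been tried, and no step for it exists in these data. For compound 4 the estimate is 5000 nM, with a range from 2000 nM to 12000 nM. This means an expected step of a 1.1-fold higher number from compound 3 to compound 4 (0.05 log units; within the scatter), not beyond the scatter.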

Compound 4, half-maximal inhibitory concentration: 1500 nM
Beside the measured number, compound 4's estimate is 3.3-fold (0.52 log units) above it; measured number outside the range, below it.
By their numbers in this assay, from the lowest: compound 4; then compounds 1, 3 and 2 (each within the scatter of the next).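

In this assay, the aromatic carbon para to a large group had seemed to tolerate any of the earlier groups, yet this position can clearly affect the result: dimethylamino in place of bromo gives a real gain (a 3.0-fold lower number from compound 3 to compound 4 (0.48 log units; beyond the scatter)), and the same holds against the unsubstituted ring (a 3.0-fold lower number from compound 1 to compound 4 (0.48 log units; beyond the scatter)). The largest step comes from replacing methyl (a 5.4-fold lower number from compound 2 to compound 4 (0.73 log units; beyond the scatter)), and with all three steps beyond the scatter, compound 4 is the most potent of the four. Nothing available explains why this group behaves differently from hydrogen, methyl and bromo.

These compounds cannot show whether the gain depends on the nitrogen or on having a larger group at this position. A simple amino group, a methoxy group or a diethylamino group on the same carbon would help separate those possibilities.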